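A few compounds are considered here, and "the series" means these few. Any claim that something is new, unique, unknown or untested is made for them only; others in the source may bear on it.

Compound 1 `CCN(Cc1ccc(Br)cc1)c1cccc(C(=O)N2CCc3ccc(OS(N)(=O)=O)cc3C2)c1` carries a sulfamate-bearing core joined through an amide to an aromatic ring that bears a (4-bromobenzyl)(ethyl)amino group. In an assay on HEK293 cells for inhibition of Steryl-sulfatase (Homo sapiens), tested at 0.1 uM (on this read-out lower numbers stand for a weaker effect and higher numbers for a stronger effect at the one concentration tested), compound 1 gives 24.2%. Compound 2 `CN(C)CCCN(Cc1ccccc1)c1cccc(C(=O)N2CCc3ccc(OS(N)(=O)=O)cc3C2)c1` keeps the same core and amide but carries a different amine on the aromatic ring, and in this assay compound 2 gives 23.8%. The two numbers lie within the usual scatter of each other, so neither compound can be set apart from the other on this read-out; compound 1 simply has one of two closely matched values.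

Compound 3 `CN(CCCN1CCCCC1)c1cccc(C(=O)N2CCc3ccc(OS(N)(=O)=O)cc3C2)c1` has not yet been measured. Relative to compound 1 the change is methyl(3-(piperidin-1-yl)propyl)amino in place of (4-bromobenzyl)(ethyl)amino on an aromatic carbon. Among the compounds with values here, no measured pair shows the effect of this exact change, so the step must be judged from the two numbers at hand. Because compound 2, which also carries a basic chain on the same aromatic carbon, gives 23.8%, the step of a number 2.2 percentage points lower from compound 1 to compound 3 (within the scatter) is expected to stay within the scatter, with no clear direction. Compound 3 is therefore estimated to give 22%, most likely between 8% and 40%.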

Compound 3, a percentage reported as inhibition, at one concentration (the size of the read-out at that concentration, not a potency): 24.1%
Beside the measured number, compound 3's estimate is 2.1 percentage points below it; measured number inside the range.
By their numbers in this assay, from the lowest: compounds 2, 3 and 1 (each within the scatter of the next).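

On this aromatic carbon, this assay gives a number 0.1 percentage points lower from compound 1 to compound 3 (within the scatter), where methyl(3-(piperidin-1-yl)propyl)amino takes the place of (4-bromobenzyl)(ethyl)amino. Within the data shown here, this is the first direct comparison at this position, and it shows that a large exchange leaves the read-out indistinguishable: the six-membered aromatic ring of carbon only and the bromine leave, while a six-membered non-aromatic ring with one hetero atom and a second nitrogen enter, with both groups counting 11 heavy atoms. No measurement of any property of these groups accompanies the result, so nothing can be said about why the number holds steady.

All the compounds shown carry a large tertiary amine group at this position, so it remains open whether a much smaller group, such as a plain amino group or a carboxylic acid, would give a number that stands clear of the scatter. As far as these compounds go, the read-out also comes from one concentration and is not a potency, so whether compound 1 and compound 3 would still match across a range of concentrations remains unknown.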